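The source may report more compounds than this note shows. Statements on the series, on what has been measured and on what is new or still open speak of the compounds shown alone.

Measured compounds:
compound 1 `COc1cc2ncnc(Nc3ccc(NC(=O)c4ccccc4C)cc3)c2cc1OC` gives 21000 nM in a functional assay on MCF7 cells (Homo sapiens) for inhibition, read by MTT assay; a higher number here means a weaker inhibitor, a lower number a stronger inhibitor;
compound 2 `COc1cc2ncnc(Nc3ccc(NC(=O)c4ccccc4Cl)cc3)c2cc1OC` gives 36000 nM;
compound 3 `COc1cc2ncnc(Nc3ccc(NC(=O)c4cccc(Cl)c4)cc3)c2cc1OC` gives 18000 nM.

Compound 3 holds the lowest of the three numbers, but the step from compound 1 to compound 3 a 1.2-fold lower number from compound 1 to compound 3 (0.07 log units; within the scatter) and the step from compound 2 to compound 3 a 2.0-fold lower number from compound 2 to compound 3 (0.30 log units; within the scatter) both stay within the scatter, so none of the three can be called a stronger inhibitor than the others. Compound 4 `COc1cc2ncnc(Nc3ccc(NC(=O)c4cc(F)ccc4Br)cc3)c2cc1OC` differs from compound 3 in one place: 2-bromo-5-fluorophenyl in place of 3-chlorophenyl on a carbonyl carbon. The measured steps that bear on it all touch the same phenyl on the carbonyl carbon: a chloro for a methyl from compound 1 to compound 2 a 1.7-fold higher number from compound 1 to compound 2 (0.23 log units; within the scatter), and a move of the chloro from compound 2 to compound 3 a 2.0-fold lower number from compound 2 to compound 3 (0.30 log units; within the scatter). Each stayed within the scatter, so no step beyond the scatter is expected in this assay for this further change. Compound 4 is therefore estimated at 20000 nM, between 9000 nM and 45000 nM. This estimate means a step of a 1.1-fold higher number from compound 3 to compound 4 (0.05 log units; within the scatter), expected to lie within the scatter.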

Compound 4, half-maximal inhibitory concentration: 26000 nM
For compound 4 the middle estimate is 1.3-fold (0.11 log units) below the measured one; the measured number falls inside the stated range.
By their numbers in this assay, from the lowest: compounds 3, 1, 4 and 2 (each within the scatter of the next).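

Placing 2-bromo-5-fluorophenyl on the carbonyl carbon puts two halogens on the ring, where the earlier compounds carried a single substituent, yet in this assay every comparison stays within the scatter: a 1.4-fold higher number from compound 3 to compound 4 (0.16 log units; within the scatter), a 1.4-fold lower number from compound 2 to compound 4 (0.14 log units; within the scatter) and a 1.2-fold higher number from compound 1 to compound 4 (0.09 log units; within the scatter). Methyl, chloro in either of the two placements shown, and the bromo and fluoro pair therefore cannot be told apart at this position in this assay. Nothing measured here accounts for this lack of separation.

On these data alone, all four compounds keep a phenyl ring with only methyl or halogen substituents, so it remains open whether an amine, a carboxylic acid or a longer alkyl chain on that ring would produce a step beyond the scatter. As far as these compounds go, whether a saturated cyclohexyl ring in place of the phenyl would do so also remains open.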